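The compounds below may be only part of what the source reports. "The series", "measured", "known", "first", "only" and "open" are said of these compounds alone.

Compound 1 `Cc1cc(C)c(NC(=O)N(Cc2ccc(N3CCN(C)CC3)cc2)C2CCCCCC2)c(C)c1` — > 1 mg/kg
Compound 2 `Cc1cc(C)c(NC(=O)N(Cc2ccc(-n3cncn3)cc2)C2CCCCCC2)c(C)c1` — > 1 mg/kg

In a functional assay on a cell-free system (plasma) with sterol O-acyltransferase, Soat (Rattus norvegicus) as the target (on this read-out lower numbers stand for an effect already at smaller amounts and higher numbers for an effect only at larger amounts of compound), compound 1 gives only a limit, > 1 mg/kg. Compound 2 likewise gives only a limit, > 1 mg/kg. The step that the two limits leave unreadable from compound 1 to compound 2 therefore cannot be read; both values sit at the limit of > 1 mg/kg in this assay, at which 2 of the 2 values shown sit. Compound 3 `Cc1cc(C)c(NC(=O)N(Cc2ccc(-n3ccnn3)cc2)C2CCCCCC2)c(C)c1` differs from compound 2 by 1H-1,2,3-triazol-1-yl in place of 1H-1,2,4-triazol-1-yl on an aromatic carbon. Among the compounds with values here, the one measured step that touches this part of the molecule, from compound 1 to compound 2, is unreadable, so it supplies no size in either direction in this assay, and nothing further among the measured compounds bears on the exchange of one triazole for the other. Compound 3 is therefore expected to remain where compound 2 stands, with the step that the limit leaves unreadable from compound 2 to compound 3 expected to be no larger than the scatter. The estimate for compound 3 is 2 mg/kg, with a range from 1 mg/kg to 10 mg/kg, and the result is expected most likely to be reported again only as a limit.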

Compound 3, dose for half-maximal effect: > 1 mg/kg
Compound 3 ended at the assay's limit; the forecaster's own chance of this, stated with the estimate: 75%; the middle value is on the limit's open side.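

In this assay compound 3 gives only a limit, > 1 mg/kg. Within the data shown here, no step among compound 1, compound 2 and compound 3 can therefore be read: the limit of > 1 mg/kg in this assay, at which 3 of the 3 values shown sit. The compounds shown leave open whether 4-methylpiperazin-1-yl, 1H-1,2,4-triazol-1-yl and 1H-1,2,3-triazol-1-yl differ at all in this assay.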